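The source may report more compounds than this note shows. Statements on the series, on what has been measured and on what is new or still open speak of the compounds shown alone.

Measured in a functional assay on cells (Mast cell, Rattus norvegicus) for inhibition, with a stated time of 15 min; on this read-out higher numbers stand for an effect only at larger amounts of compound and lower numbers for an effect already at smaller amounts:
Compound 1 `O=C(Nc1nnn[nH]1)c1cc(=O)c2ccccc2o1`: 0.08 ug/mL
Compound 2 `O=C(O)CCNC(=O)c1cc(=O)c2ccccc2o1`: > 18 ug/mL, a limit of the assay and not a number
Compound 3 `Cc1ccc2oc(C(=O)Nc3nnn[nH]3)cc(=O)c2c1`: 0.075 ug/mL

In this assay, compound 1 stands level with compound 3, as the step of a 1.1-fold lower number from compound 1 to compound 3 (0.03 log units; within the scatter) shows. Compound 4 `O=C(Nc1nnn[nH]1)c1oc2ccccc2c(=O)c1Cl` has not yet been measured. It differs from compound 1 by one change: chloro in place of hydrogen on an aromatic carbon. The chloro sits on an aromatic carbon of the six-membered aromatic ring with 1 oxygen, ortho to a group of 8 heavy atoms.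

Among the measured compounds shown here, two measured steps bear on this, neither directly. The step of a 1.1-fold lower number from compound 1 to compound 3 (0.03 log units; within the scatter) also replaces hydrogen on an aromatic carbon, but with methyl and at another place on the core. The step of an at least 220-fold higher number from compound 1 to compound 2 (2.35 log units; beyond the scatter) alters the group on the amide-type nitrogen, which compound 4 keeps, and shows only that this read-out can move strongly within the series.

A modest move towards a higher number is therefore expected, possibly not beyond the scatter. The expected change is a 2.5-fold higher number from compound 1 to compound 4 (0.40 log units; beyond the scatter). For compound 4 the estimated value is 0.2 ug/mL. The expected range for compound 4 runs from 0.05 ug/mL to 1.5 ug/mL.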

Compound 4, concentration for half-maximal effect: 0.8 ug/mL
For compound 4 the middle estimate is 4.0-fold (0.60 log units) below the measured one, within the range that was stated.
By their numbers in this assay, from the lowest: compounds 3 and 1 (each within the scatter of the next); then compound 4. At a limit, above all of these: compound 2.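

This position, on an aromatic carbon two atoms from the ring oxygen and ortho to a group of 8 heavy atoms, proves sensitive to substitution: in this assay, chloro in place of hydrogen gives a 10-fold higher number from compound 1 to compound 4 (1.00 log units; beyond the scatter). The earlier compounds shown here showed no such sensitivity on the aromatic carbons of the core, since methyl at another place gave only a 1.1-fold lower number from compound 1 to compound 3 (0.03 log units; within the scatter). Nothing in the data shown accounts for the step to compound 4.

The compounds shown do not tell whether the rise belongs to chloro itself or would follow any group on this carbon, such as an amine or a carboxylic acid. Nor do they tell how chloro would behave on the carbon that bears the methyl of compound 3.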